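Methyl-to-hydrogen step on the aryl group of compound 1

This account rests on a few compounds, and the source may have more. Where it says the series, first, only, none or still open, it means among the compounds named here.

In a functional assay on HT-29 cells (Homo sapiens) for cytotoxicity, read by MTT assay, with a stated time of 48 h, tested at 100 uM (on this read-out higher numbers stand for a stronger effect at the one concentration tested and lower numbers for a weaker effect), the measured compounds read:
compound 1 `Cc1ccc(C2=Nn3c(Cc4ccc(S(C)(=O)=O)cc4)nnc3SC2)cc1` gives 38.5%
compound 2 `CS(=O)(=O)c1ccc(Cc2nnc3n2N=C(c2cc4ccccc4c(=O)o2)CS3)cc1` gives 10.6%
compound 3 `CS(=O)(=O)c1ccc(Cc2nnc3n2N=C(c2cc(Cl)sc2Cl)CS3)cc1` gives 47.3%

Compound 1 holds the second highest of the three numbers. The nearest is compound 3, with the step of a number 8.8 percentage points higher from compound 1 to compound 3 (within the scatter), which stays within the scatter. Among the compounds with values here, compound 2 gives a lower number than compound 1, and that gap lies beyond the scatter; no single-point step connects the two.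

Compound 4 `CS(=O)(=O)c1ccc(Cc2nnc3n2N=C(c2ccccc2)CS3)cc1` differs from compound 1 by hydrogen in place of methyl on an aromatic carbon. Within the data shown here, no measured step touches the methyl alone; the only step on record, a number 8.8 percentage points higher from compound 1 to compound 3 (within the scatter), replaces the whole aryl group and still falls within the scatter. The change to compound 4 is therefore expected to give a step of a number 3.5 percentage points lower from compound 1 to compound 4 (within the scatter) that stays within the scatter. Compound 4 is estimated at 35%, in the range 20% to 50%.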

Compound 4, a percentage reported as activity, at one concentration (the size of the read-out at that concentration, not a potency): 55.5%
The estimate for compound 4 lay 20.5 percentage points below the measured number; measured number above the stated range.
By their numbers in this assay, from the lowest: compound 2; then compounds 1, 3 and 4 (each within the scatter of the next, the first and the last beyond it).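

In this assay, hydrogen in place of methyl on the aromatic carbon gives a number 17 percentage points higher from compound 1 to compound 4 (beyond the scatter), so this single position alone can move the read-out beyond the scatter, which the whole-aryl replacement in compound 3 did not show. Phenyl in place of 2,5-dichlorothiophen-3-yl gives a number 8.2 percentage points higher from compound 3 to compound 4 (within the scatter), leaving those two aryl groups unseparated. No evidence on the cause accompanies this result.

From the compounds shown here alone, how an amine or a methoxy group on that aromatic carbon would read remains open. Going by these compounds, whether the step holds as a difference in potency also remains open, as each number comes from one concentration.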